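Aryl swap on the sulfonamide piperazine of a xanthine core

The source may hold more compounds than are shown below. What is called first, only, known or untested is meant among the compounds shown, and "the series" means these compounds.

Measured so far:
- compound 1 `CCCn1c(=O)[nH]c2nc(-c3ccc(S(=O)(=O)N(C)C)cc3)[nH]c2c1=O`: 190 nM
- compound 2 `CCCn1c(=O)[nH]c2nc(-c3ccc(S(=O)(=O)N4CCN(c5ccccc5C)CC4)cc3)[nH]c2c1=O`: 419 nM

In an assay on CHO cells for displacement of a labelled ligand from adenosine receptor A1 (Homo sapiens), read by scintillation counting, with a stated time of 90 min, in the presence of a further agent that is not named here (a lower number here means a stronger inhibitor, a higher number a weaker inhibitor), compound 1 gives 190 nM and compound 2 gives 419 nM, so compound 2 stands as the higher of the two numbers, and its gap to compound 1 lies beyond the usual scatter. Compound 3 `CCCn1c(=O)[nH]c2nc(-c3ccc(S(=O)(=O)N4CCN(c5cccc(Br)c5)CC4)cc3)[nH]c2c1=O` differs from compound 2 by 3-bromophenyl in place of 2-methylphenyl on an amine nitrogen in a ring. Within the data shown here, no measured pair shows what such a swap does, so only a small step, if any, is expected for the change from compound 2 to compound 3, of size a 1.0-fold lower number from compound 2 to compound 3 (0.02 log units; within the scatter) and in no set direction. Compound 3 is therefore estimated at 400 nM, within a range from 150 nM to 1100 nM.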

Compound 3, inhibition constant: > 1000 nM
Compound 3: a limit, no number; the forecaster's own chance of this, stated with the estimate: 3%; middle value at least 2.5-fold (0.39 log units) away from the limit.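

In this assay compound 3 gives > 1000 nM, which is a limit of the assay and not a number: the limit of > 1000 nM in this assay, at which 1 of the 3 values shown sits.

Even so, putting 3-bromophenyl in place of 2-methylphenyl on the amine nitrogen in a ring gives an at least 2.3-fold higher number from compound 2 to compound 3 (0.37 log units; beyond the scatter), although both groups count 7 heavy atoms. Among these compounds, the earlier compounds held only one aryl group here, so only now does the choice of that group show up as a change in the number.

From the compounds shown here alone, whether the bromine, its place on the ring or the loss of the methyl carries this step stays open. A plain phenyl or a 3-methylphenyl at this position would help to separate these.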